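A few compounds are considered here, and "the series" means these few. Any claim that something is new, unique, unknown or untested is made for them only; others in the source may bear on it.

Measured so far:
compound 1 `Fc1ccc(-c2nn3c(NC4CCCC4)cccc3c2-c2ccc(NC3CCCC3)nc2)cc1` — "not determined" (no result reported)
compound 2 `Fc1ccc(-c2nn3c(NC4CCCC4)cccc3c2-c2cccnc2)cc1` — > 40000 nM
compound 3 `Fc1ccc(-c2nn3c(NC4CCCC4)cccc3c2-c2ccnc(NC3CCCC3)c2)cc1` — > 40000 nM

Three compounds on the shared core have been taken through an ADME assay on Vero cells (Chlorocebus sabaeus) for cytotoxicity; on this read-out lower numbers stand for higher toxicity in this test and higher numbers for lower toxicity in this test. Compound 2 gives > 40000 nM, which is a limit of the assay and not a number. Compound 3 likewise gives > 40000 nM, again a limit. For compound 1 the result is "not determined" (no result reported). Compound 2 therefore stands at the limit of > 40000 nM in this assay, at which 2 of the 3 values shown sit, with nothing in the shown values that sets it apart from compound 3, and no step between measured compounds has been recorded.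

Compound 4 `Fc1ccc(-c2nn3c(NC4CCCC4)cccc3c2-c2cn[nH]c2)cc1` is the next one to be measured in this assay . Relative to compound 2 its change is 1H-pyrazol-4-yl in place of pyridin-3-yl on an aromatic carbon. With only limits on hand for compound 2 and compound 3, the expectation for compound 4 rests on those limits alone. The step from compound 2 to compound 4 is estimated as a number no higher from compound 2 to compound 4 (the limit leaves the size open), which is none beyond the scatter. Compound 4 is accordingly expected to give about 40000 nM in this assay , within a range of 20000 nM to 80000 nM, and most likely to be reported as a limit once more.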

Compound 4, half-maximal cytotoxic concentration: 10000 nM
For compound 4 the middle estimate is 4.0-fold (0.60 log units) above the measured one; measured number outside the range, below it.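

On the aromatic carbon of the five-membered aromatic ring, two ring bonds from the ring nitrogen, the choice of group is not silent in this assay: 1H-pyrazol-4-yl in place of pyridin-3-yl gives an at least 4.0-fold lower number from compound 2 to compound 4 (0.60 log units; beyond the scatter). Compound 4 is the only compound shown that gives a single number instead of a limit, so this position can move the read-out toward higher toxicity in this test, and the change that does so replaces a six-membered aromatic ring without a hydrogen-bond donor by a five-membered one with a hydrogen-bond donor. The full size of the step stays open, since the value for compound 2 is a limit: the limit of > 40000 nM in this assay, at which 2 of the 4 values shown sit.

The compounds shown leave open whether the step goes with the hydrogen-bond donor or with the five-membered ring itself, a question that a 1-methyl-1H-pyrazol-4-yl group, with a methyl on the ring nitrogen in place of its hydrogen, would address. They also leave open how other five-membered rings at this position, such as a thiazole or an imidazole, would read in this assay.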